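Aminocyclohexyl in Place of a Dimethylaminopropyl Chain

A few compounds are considered here, and "the series" means these few. Any claim that something is new, unique, unknown or untested is made for them only; others in the source may bear on it.

Measured compounds:
Compound 1, `N[C@H]1CC[C@H](Nc2c(C(=O)NCc3ccc(F)cc3)nc(N3CCCCS3(=O)=O)c3cccnc23)CC1`: in a functional assay on HT-29 cells (Homo sapiens) for cytotoxicity, read by MTT assay, with a stated time of 72 h (a higher number here means a weaker inhibitor, a lower number a stronger inhibitor), compound 1 gives > 10000 nM, which is a limit of the assay rather than a number.
Compound 2, `CN(C)CCCNc1c(C(=O)NCc2ccc(F)cc2)nc(Br)c2cccnc12`: in this assay compound 2 gives 6000 nM.

Within the data shown here, compound 2 is therefore the only compound of the two with a number in this assay; the other value shown is a limit. The unmeasured compound 3, `N[C@H]1CC[C@H](Nc2c(C(=O)NCc3ccc(F)cc3)nc(Br)c3cccnc23)CC1`, differs from compound 2 in one place: 4-aminocyclohexyl in place of 3-(dimethylamino)propyl on a nitrogen on an aromatic ring. The bromine and the fluorobenzyl amide of compound 2 are kept, so the change is confined to the side chain on the nitrogen on the aromatic ring.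

Among the measured compounds shown here, no step between measured compounds exists here, so the size of this change cannot be read from a measured pair. Compound 1 carries the same 4-aminocyclohexyl group, though it also differs at a second place, and in this assay compound 1 sits at a limit, (the limit of > 10000 nM in this assay, at which 1 of the 2 values shown sits). The step of a 1.3-fold higher number from compound 2 to compound 3 (0.12 log units; within the scatter) is therefore expected to be small, toward weaker inhibition or not beyond the usual scatter. Compound 3 is expected to give about 8000 nM, within a range from 2500 nM to 20000 nM.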

Compound 3, half-maximal inhibitory concentration: < 1000 nM
Compound 3: a limit, no number; the forecaster's own chance of this, stated with the estimate: 40%; middle value at least 8.0-fold (0.90 log units) from the limit.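

Among these compounds, on a nitrogen on an aromatic ring, the side chain matters in this assay, which the earlier compounds could not show: 4-aminocyclohexyl in place of 3-(dimethylamino)propyl gives an at least 6.0-fold lower number from compound 2 to compound 3 (0.77 log units; beyond the scatter). With 4-aminocyclohexyl kept, the group on the aromatic carbon matters as well, since one bromine atom in place of the group of 8 heavy atoms, with its six-membered non-aromatic ring, gives an at least 10-fold lower number from compound 1 to compound 3 (1.00 log units; beyond the scatter). Compound 3 itself gives a limit of the assay and not a number: the limit of < 1000 nM in this assay, at which 1 of the 3 values shown sits.

Going by these compounds, how far the true values lie beyond these limits stays open, and compound 1 also gives a limit and not a number: the limit of > 10000 nM in this assay, at which 1 of the 3 values shown sits. Also open is whether the gain follows the ring or the primary amine of 4-aminocyclohexyl, which a plain cyclohexyl group or an open-chain 3-aminopropyl group on the same nitrogen would separate, and whether a chlorine atom could stand in for the bromine atom.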